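A few compounds are considered here, and "the series" means these few. Any claim that something is new, unique, unknown or untested is made for them only; others in the source may bear on it.

Compound 1 `O=C(CSc1nnnn1-c1cccc2ccccc12)N/N=C/c1ccccc1F` is one of three close relatives tested in an ADME assay on MT4 cells (Homo sapiens) for cytotoxicity, read by MTT assay; a lower number here means that less compound is tolerated, a higher number that more compound is tolerated. For compound 1 the value is a limit of the measurement rather than a number, >= 118000 nM. Compound 2 `O=C(CSc1nnnn1-c1cccc2ccccc12)N/N=C/c1ccc(F)cc1` likewise reaches only a limit of this assay, > 307000 nM. Compound 3 `Cc1cccc(/C=N/NC(=O)CSc2nnnn2-c2cccc3ccccc23)c1` gives a number, 269000 nM. Where compound 1 stands among the three cannot be fixed closely, since its own value is a limit and so is one of the other two; both steps out of compound 1 stay unreadable, a step that the two limits leave unreadable from compound 1 to compound 2 and a step that the limit leaves unreadable from compound 1 to compound 3. Going by the values given here, the one readable step, an at least 1.1-fold lower number from compound 2 to compound 3 (0.05 log units; that floor lies within the scatter), lies within the scatter, so the three compounds, as far as they are read, sit in the same region of high tolerated concentration.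

Compound 4 `O=C(CSc1nnnn1-c1cccc2ccccc12)N/N=C/c1ccccc1O` has not yet been measured. It differs from compound 1 by hydroxy in place of fluoro on an aromatic carbon. Among the compounds with values here, none of the measured steps concerns this exchange, and the two steps leaving compound 1 are unreadable, so the expectation rests only on the shared region of the three relatives. Compound 4 is therefore expected to give 200000 nM, estimated between 100000 nM and 400000 nM, with no shift beyond the scatter. The expected step is a step that the limit leaves unreadable from compound 1 to compound 4.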

Compound 4, half-maximal cytotoxic concentration: 4850 nM
Estimate against measurement, compound 4: 41-fold (1.62 log units) above; the whole stated range lies above it.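

In this assay, the group on this aromatic carbon, ortho to a large group, proves decisive, which the three earlier compounds could not show: hydroxy in place of fluoro gives an at least 24-fold lower number from compound 1 to compound 4 (1.38 log units; beyond the scatter). The other two relatives confirm that compound 4 stands apart, with a 55-fold lower number from compound 3 to compound 4 (1.74 log units; beyond the scatter) and an at least 63-fold lower number from compound 2 to compound 4 (1.80 log units; beyond the scatter), so among these four compounds the 2-hydroxyphenyl group goes with the lowest tolerated concentration, while the 2-fluorophenyl, 4-fluorophenyl and 3-methylphenyl compounds all remain far higher. The value of compound 1 is a limit, so the step from it gives a minimum size and not an exact one: the limit of >= 118000 nM in this assay, at which 1 of the 4 values shown sits.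

A methoxy group or an amine on the same carbon would help show whether this large step belongs to hydroxy alone or extends to other groups that replace fluoro there. Hydroxy on another carbon of the ring would show whether the place matters as much as the group, and the compounds shown give no reason for the lower tolerated concentration of compound 4.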